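Cyclohexyl for Butyl: Cytotoxicity Outlook for Compound 4

This account rests on a few compounds, and the source may have more. Where it says the series, first, only, none or still open, it means among the compounds named here.

Three compounds have so far been measured in an ADME assay on RD cells (Homo sapiens) for cytotoxicity, read by MTT assay, with a stated time of 3 days; on this read-out lower numbers stand for higher toxicity in this test and higher numbers for lower toxicity in this test:

compound 1, `CC[C@@H](CCn1cncn1)c1ccccc1`: 91.2 ug/mL
compound 2, `CCCC[C@@H](CCn1cncn1)c1ccccc1`: 47.5 ug/mL
compound 3, `CCCC[C@@H](CCn1cncn1)c1ccc(F)cc1`: 34.1 ug/mL

Compound 2 stands second highest of these three numbers. Its nearest neighbour is compound 3, reached by a 1.4-fold lower number from compound 2 to compound 3 (0.14 log units; within the scatter), and its furthest is compound 1, from which a 1.9-fold lower number from compound 1 to compound 2 (0.28 log units; within the scatter) leads to compound 2; both steps lie within the scatter.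

Compound 4, `c1ccc([C@H](CCn2cncn2)C2CCCCC2)cc1`, differs from compound 2 by cyclohexyl in place of butyl on a saturated chain carbon bound to an aromatic carbon and a saturated chain carbon. Of the measured steps, a 1.9-fold lower number from compound 1 to compound 2 (0.28 log units; within the scatter) bears most on this change, since it also enlarges the same saturated chain carbon region bound to the aromatic ring, whereas a 1.4-fold lower number from compound 2 to compound 3 (0.14 log units; within the scatter) alters the aromatic ring and says little here. That chain enlargement produced only a step within the scatter, and the group entering in compound 4 is again the larger one by the counts given. Compound 4 is therefore expected to give a modest step toward a lower number, a 1.6-fold lower number from compound 2 to compound 4 (0.20 log units; within the scatter), which may not exceed the scatter. Compound 4 is estimated at 30 ug/mL, with a range from 14 ug/mL to 65 ug/mL.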

Compound 4, half-maximal cytotoxic concentration: 11.8 ug/mL
Compound 4: middle estimate off by 2.5-fold (0.41 log units), on the high side; measured number below the stated range.
By their numbers in this assay, from the lowest: compound 4; then compounds 3, 2 and 1 (each within the scatter of the next, the first and the last beyond it).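

At the saturated chain carbon bound to an aromatic carbon and a saturated chain carbon, cyclohexyl in place of butyl gives in this assay a 4.0-fold lower number from compound 2 to compound 4 (0.60 log units; beyond the scatter), which lies beyond the scatter and so points to higher toxicity in this test, whereas the earlier change in this region, a 1.9-fold lower number from compound 1 to compound 2 (0.28 log units; within the scatter), stayed within it. Cyclohexyl in place of ethyl at the same place gives a 7.7-fold lower number from compound 1 to compound 4 (0.89 log units; beyond the scatter), also beyond the scatter, so the group on this carbon can move the number by more than the earlier compounds showed, and the ring-bearing group is the one that does so here. Nothing measured explains the size of these steps, and the compounds shown cannot separate the ring itself from the larger number of carbons that enters with it.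

A longer open chain such as hexyl, or a smaller ring such as cyclopentyl, would be needed at this carbon to tell those two apart. Going by these compounds, it also remains open whether a cyclohexyl carrying an amine or a hydroxyl would keep the lower number, and whether fluoro on the aromatic ring would change the outcome alongside cyclohexyl.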